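Methyl for fluoro on an inactive aromatic core

This account rests on a few compounds, and the source may have more. Where it says the series, first, only, none or still open, it means among the compounds named here.

Compound 1 `Fc1ccc(-c2noc3c2CCNCC3)cc1` has been tested in an assay on cells for displacement of a labelled ligand from 5-hydroxytryptamine receptor 1B (Homo sapiens), read by scintillation counting, with a stated time of 1.5 h (a lower number here means a stronger inhibitor, a higher number a weaker inhibitor), and there it reaches only the limit of the assay, > 10000 nM, so that no number is known for it. Two further compounds on a related core have the same fate. Compound 2 `Cc1ccc(-c2n[nH]c3c2CCNCC3)cc1` gives in this assay only the limit > 10000 nM. Compound 3 `Fc1ccc(-c2n[nH]c3c2CCNCC3)cc1` gives in this assay only the limit > 10000 nM. Going by the values given here, the one step available between measured compounds, a step that the two limits leave unreadable from compound 2 to compound 3, is therefore of unreadable size, and all that can be said is what the limit of > 10000 nM in this assay, at which 3 of the 3 values shown sit, states.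

Compound 4 `Cc1ccc(-c2noc3c2CCNCC3)cc1` is the counterpart of compound 1 that carries methyl in place of fluoro on an aromatic carbon, that is, methyl in place of fluoro on an aromatic carbon. Among the compounds with values here, the only measured step that bears on this change runs in the opposite direction on the other core and cannot be read, so no size or direction can be taken from it. With three of three values sitting at the limit, compound 4 is expected to sit there as well, with a step that the limit leaves unreadable from compound 1 to compound 4 that means no change beyond the scatter. For compound 4 the estimated value in this assay is 20000 nM, within the range from 8000 nM to 60000 nM.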

Compound 4, inhibition constant: > 10000 nM
Compound 4: a limit, no number; the forecaster's own chance of this, stated with the estimate: 85%; the middle value lies beyond the limit too.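

In this assay compound 4 gives > 10000 nM, a limit and not a number. Compound 1 also gives only a limit, so no step can be read between compound 1 and compound 4: the limit of > 10000 nM in this assay, at which 4 of the 4 values shown sit.

The compounds shown leave open whether methyl and fluoro differ at all, and what would bring measurable binding in this assay.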